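The source may hold more compounds than are shown below. What is called first, only, known or untested is meant among the compounds shown, and "the series" means these compounds.

Of the compounds shown here, two sharing one core have so far been measured in an ADME assay on HepG2 cells (Homo sapiens) for cytotoxicity, read by CellTiter-Glo and resazurin assay, with a stated time of 72 h; on this read-out lower numbers stand for an effect already at smaller amounts and higher numbers for an effect only at larger amounts of compound. Compound 1 `CC(C)N(Cc1cccc(OCCCCCC(=O)O)c1)C(=O)c1ccc(-c2cccc3ccccc23)cc1` gives > 26000 nM in this assay, which is a limit of the assay and not a number. Compound 2 `CC(=O)Nc1cccc(-c2ccc(C(=O)N(Cc3cccc(OCCCCCC(=O)O)c3)C(C)C)cc2)c1` gives > 26000 nM in this assay, again a limit rather than a measured number. The step that the two limits leave unreadable from compound 1 to compound 2 therefore cannot be sized, and the whole picture rests on (the limit of > 26000 nM in this assay, at which 2 of the 2 values shown sit). Compound 3 `CC(C)N(Cc1cccc(OCCCCCC(=O)O)c1)C(=O)c1ccc(-c2ccncc2)cc1` differs from compound 2 by pyridin-4-yl in place of 3-acetamidophenyl on an aromatic carbon. Going by the values given here, no measured step reads on this change, so there is no basis for expecting a move beyond the scatter in either direction, only that compound 3 may again reach the same limit. Compound 3 is therefore estimated at 26000 nM in this assay, with a range from 9000 nM to 80000 nM. The step that this estimate means, a number no higher from compound 2 to compound 3 (the limit leaves the size open), is expected to stay within the scatter.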

Compound 3, half-maximal effective concentration: > 26000 nM
Compound 3: no number, only a limit; the forecaster's own chance of this, stated with the estimate: 75%; the middle value sits exactly at the limit.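

In this assay compound 3 gives > 26000 nM, a limit of the assay and not a number. Going by these compounds alone, no step between compound 1, compound 2 and compound 3 can therefore be read: the limit of > 26000 nM in this assay, at which 3 of the 3 values shown sit. The compounds shown leave open at what concentration any of them reaches its half-maximal effect, and whether changing this one group shifts that concentration.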